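The source may report more compounds than this note shows. Statements on the series, on what has been measured and on what is new or still open speak of the compounds shown alone.

Compound 1, `Cc1cccc(Oc2cccc(COc3ccccc3CCC(=O)OCCCOP(=O)(O)OC[C@H](N)C(=O)O)c2)c1`, gives 21.3% in an assay on cells for agonist activity at probable G-protein coupled receptor 34 (Mus musculus), with a stated time of 1 h; a lower number here means a smaller maximal response, a higher number a larger maximal response.
Compound 2, `Cc1ccc(Oc2cccc(COc3ccccc3CCC(=O)OCCCOP(=O)(O)OC[C@H](N)C(=O)O)c2)cc1`, gives 18.2% in this assay.

Among the measured compounds shown here, compound 2 holds the lower of the two numbers in this assay, but its only neighbour, compound 1, sits so close that a number 3.1 percentage points lower from compound 1 to compound 2 (within the scatter) says nothing about a real difference between the two. The next compound, compound 3, `N[C@@H](COP(=O)(O)OCCCOC(=O)CCc1ccccc1OCc1cccc(Oc2ccccc2Cl)c1)C(=O)O`, differs from compound 2 in one place: 2-chlorophenyl in place of 4-methylphenyl on an oxygen on an aromatic ring. For the measured compounds named here, the only measured step that bears on this change is the one between compound 1 and compound 2, where a different methylphenyl was exchanged on the same oxygen, and it stayed within the scatter. With nothing further to go on, compound 3 is expected to stay near compound 2, so that a number 0.8 percentage points higher from compound 2 to compound 3 (within the scatter) is estimated to be a step of no more than ordinary size. Compound 3 is therefore estimated at 19% in this assay, in a range from 8% to 32%.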

Compound 3, largest response reached (Emax), in percent of the reference or control that the assay uses: 19.8%
For compound 3 the middle estimate is 0.8 percentage points below the measured one, and the stated range covers the measured number.
By their numbers in this assay, from the lowest: compounds 2, 3 and 1 (each within the scatter of the next).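

The exchange on this oxygen now extends beyond methylphenyl groups: with 2-chlorophenyl in place of 4-methylphenyl, the result is a number 1.6 percentage points higher from compound 2 to compound 3 (within the scatter), and with 2-chlorophenyl in place of 3-methylphenyl, it is a number 1.5 percentage points lower from compound 1 to compound 3 (within the scatter). Chlorine thus replaces carbon in the entering group, and the group's place of substitution on the ring also differs, yet all three compounds remain within the scatter of one another in this assay. No measurement shown here gives a reason for this closeness.

From the compounds shown here alone, whether an amine, a carboxylic acid or a longer chain on this aromatic ring would give a step beyond the scatter remains open. Going by these compounds, it is also open whether 3-chlorophenyl or 4-chlorophenyl would stay as close as 2-chlorophenyl does.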